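A few compounds are considered here, and "the series" means these few. Any claim that something is new, unique, unknown or untested is made for them only; others in the source may bear on it.

Going by the values given here, compound 1 `Oc1ccccc1-c1cc(-c2cccc(F)c2)cc(-c2ccccc2O)n1` is one of only two compounds that have been put through a functional assay on T47D cells (Homo sapiens) for inhibition; a higher number here means a weaker inhibitor, a lower number a stronger inhibitor. In this assay compound 1 gives > 50000 nM, which is a limit of the assay and not a measured number. Compound 2 `Oc1ccc(-c2cc(-c3cccc(F)c3)cc(-c3ccccc3O)n2)cc1` is the other measured compound. In this assay compound 2 gives > 50000 nM, again a limit rather than a number. Among the compounds with values here, the one measured step, a step that the two limits leave unreadable from compound 1 to compound 2, therefore cannot be read in size or direction, since the limit of > 50000 nM in this assay, at which 2 of the 2 values shown sit, describes where both values sit. Compound 3 `Oc1ccccc1-c1cc(-c2ccccc2C(F)(F)F)cc(-c2ccccc2O)n1` is the unmeasured compound, and it differs from compound 1 by 2-(trifluoromethyl)phenyl in place of 3-fluorophenyl on an aromatic carbon. Within the data shown here, no measured step bears on this change, and the only comparison available, that from compound 1 to compound 2, is itself unreadable. With both measured values sitting at the limit, the expectation for compound 3 is that it also returns a limit, and the step that the limit leaves unreadable from compound 1 to compound 3 is estimated as no readable change. Compound 3 is thus expected to give 70000 nM, within a range from 20000 nM to 250000 nM.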

Compound 3, half-maximal inhibitory concentration: 22500 nM
Compound 3: middle estimate off by 3.1-fold (0.49 log units), on the high side, within the range that was stated.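

In this assay, the group opposite the ring nitrogen proves able to move the read-out: 2-(trifluoromethyl)phenyl in place of 3-fluorophenyl gives an at least 2.2-fold lower number from compound 1 to compound 3 (0.34 log units; beyond the scatter), the direction of a stronger inhibitor. Going by these compounds alone, compound 3, at 22500 nM, is the only one of the three compounds with a measured number, whereas the earlier pair offered only a step that cannot be read. The new step is a lower bound on the change and its true size stays unknown, because the other two compounds sit at a limit of the assay and not at numbers: the limit of > 50000 nM in this assay, at which 2 of the 3 values shown sit.

This single change replaces fluorine with trifluoromethyl and also moves the substituent to a different place on the phenyl ring, so the compounds shown do not tell which of the two accounts for the step. They also leave open how an unsubstituted phenyl, or a phenyl carrying an amine or a carboxylic acid, would read at this position, and whether any such group would bring the number much lower.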